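Hydroxy for Azido on a Selenium Sugar: Cytotoxicity Outlook

A few compounds are considered here, and "the series" means these few. Any claim that something is new, unique, unknown or untested is made for them only; others in the source may bear on it.

Four compounds built on a five-membered non-aromatic ring with one selenium are compared in a functional assay on A549 cells (Homo sapiens) for cytotoxicity, read by sulforhodamine B assay; on this read-out higher numbers stand for weaker inhibition and lower numbers for stronger inhibition. Compound 1 `[N-]=[N+]=N[C@@H]1C(n2ccc(=O)[nH]c2=O)[Se][C@H](CO)[C@H]1O` carries an azido group on a saturated ring carbon; in this assay compound 1 gives only a limit, > 100000 nM. Compound 2 `O=c1ccn(C2[Se][C@H](CO)[C@@H](O)[C@@H]2O)c(=O)[nH]1` differs by hydroxy in place of azido on a saturated ring carbon and in this assay compound 2 likewise gives only a limit, > 100000 nM. The step that the two limits leave unreadable from compound 1 to compound 2 therefore cannot be sized. Going by the values given here, compound 3 `[N-]=[N+]=N[C@@H]1C(n2ccc(N)nc2=O)[Se][C@H](CO)[C@H]1O` is the one member with a number: in this assay compound 3 gives 80100 nM. How the core of compound 3 differs from the core of compound 1 is not broken down here. Compound 4 `Nc1ccn(C2[Se][C@H](CO)[C@@H](O)[C@@H]2O)c(=O)n1` differs from compound 3 by hydroxy in place of azido on a saturated ring carbon, the same change as from compound 1 to compound 2. Two of the three values sit at the limit of > 100000 nM in this assay, at which 2 of the 3 values shown sit. Among the compounds with values here, because the limit of > 100000 nM in this assay, at which 2 of the 3 values shown sit, holds two of the three values and compound 3 is the only one with a number, the step of a 1.6-fold higher number from compound 3 to compound 4 (0.21 log units; within the scatter) is expected to be small. The estimate for compound 4 is 130000 nM, with a plausible span from 40000 nM to 400000 nM.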

Compound 4, half-maximal inhibitory concentration: 8830 nM
Beside the measured number, compound 4's estimate is 15-fold (1.17 log units) above it; the measured number lies below the stated range.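

In this assay, hydroxy in place of azido on a saturated ring carbon gives a 9.1-fold lower number from compound 3 to compound 4 (0.96 log units; beyond the scatter), so on the core of compound 3 the change can be read and it goes towards stronger inhibition. The same change on the core of compound 1 cannot be read, because compound 1 and compound 2 each stand only at a limit: the limit of > 100000 nM in this assay, at which 2 of the 4 values shown sit. The result therefore shows what the change does on one core only; it does not show that the step carries over to the core of compound 1 with the same size or even the same direction.

The compounds shown leave open whether an amine or a fluoro group in that same place on a saturated ring carbon would follow azido or hydroxy on either core. They also leave open whether a longer chain in place of the hydroxymethyl group would alter the number seen for compound 4.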